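This account rests on a few compounds, and the source may have more. Where it says the series, first, only, none or still open, it means among the compounds named here.

Of the compounds shown here, three share one core and have already been measured. Compound 1, `CCCCOC(=O)Nc1ccc(S(=O)(=O)N2C[C@H](c3ccccc3)NC2=O)cc1CC`, carries different groups on its aromatic ring from the others; in a functional assay on NCI-H460 cells (Homo sapiens) for cytotoxicity, read by MTT assay (a lower number here means a stronger inhibitor, a higher number a weaker inhibitor), compound 1 gives 200 nM. Compound 2, `Cc1cc(S(=O)(=O)N2C(=O)N[C@@H](c3ccccc3)C2C)ccc1NC(=O)c1ccc(N)cc1`, carries a methyl group and an amide built from an aminobenzoic acid. In this assay compound 2 reaches only the limit of the assay, > 10000 nM, so no number is known for it. Compound 3, `Cc1cc(S(=O)(=O)N2C(=O)N[C@@H](c3ccccc3)C2C)ccc1NC(=O)c1ccc([N+](=O)[O-])cc1`, has a nitro group where compound 2 has an amino group. In this assay compound 3 likewise sits at the limit, > 10000 nM. The step that the two limits leave unreadable from compound 2 to compound 3 cannot be sized, because both values rest at the limit of > 10000 nM in this assay, at which 2 of the 3 values shown sit. Compound 4, `CC1[C@H](c2ccccc2)NC(=O)N1S(=O)(=O)c1ccc(NC(=O)c2ccc(N)cc2)c(Cl)c1`, differs from compound 2 by chloro in place of methyl on an aromatic carbon. Among the compounds with values here, no measured step resembles this exchange of one small group for another on the aromatic ring, and compound 2 itself supplies only a limit, so nothing points in either direction. Compound 4 is therefore expected to stay near the limit as well, with the step of a number no higher from compound 2 to compound 4 (the limit leaves the size open) estimated to be no change beyond the scatter. The estimate for compound 4 is 10000 nM, within a range from 2500 nM to 40000 nM.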

Compound 4, half-maximal inhibitory concentration: > 10000 nM
Compound 4 ended at the assay's limit (the forecaster's own chance of this, stated with the estimate: 60%); the middle value lies on the limit itself.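

Compound 4 gives > 10000 nM in this assay, which is a limit and not a number. No size can be read for the exchange of methyl for chloro between compound 2 and compound 4, because both sit at a limit: the limit of > 10000 nM in this assay, at which 3 of the 4 values shown sit.

The compounds shown leave open whether chloro in place of methyl changes the result in this assay at all.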